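The source may hold more compounds than are shown below. What is called first, only, known or untested is meant among the compounds shown, and "the series" means these compounds.

The measured compounds are:

compound 1, `O=C(O)COc1ccc(NCc2cccc(Oc3ccccc3)c2)cc1`, with 84% in a functional assay on CHO cells for agonist activity at Free fatty acid receptor 1 (Homo sapiens), read by a luciferase reporter; on this read-out higher numbers stand for larger maximal responses and lower numbers for smaller maximal responses;
compound 2, `Cc1nc(-c2ccc(C(F)(F)F)cc2)sc1CNc1ccc(C(C)CC(=O)O)cc1`, with 109%;
compound 3, `Cc1nc(-c2ccc(C(F)(F)F)cc2)sc1CNc1ccc([C@H]2C[C@@H]2C(=O)N[C@H](C)c2ccccc2)cc1`, with 42%.

Among these three maximal responses, compound 1 holds the second highest. Compound 2 lies closest to it, with a number higher by a margin that is beyond the scatter, and compound 3 lies furthest from it, with a number lower by a margin that is also beyond the scatter.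

Compound 4, `O=C(NO)[C@H]1C[C@@H]1c1ccc(NCc2cccc(Oc3ccccc3)c2)cc1`, has not yet been measured. It is derived from compound 1 by one change on an aromatic carbon of the shared core, para to a large group: 2-(hydroxycarbamoyl)cyclopropyl in place of carboxymethoxy on an aromatic carbon. The carboxymethoxy of compound 1 is thus gone, and the new group keeps a hydrogen-bond donor count of two and an acceptor count of two, with two defined stereocentres on the three-membered ring.

Within the data shown here, no measured pair in this set reports this exact change. Among the measured compounds shown here, the only compound without a carboxylic acid, compound 3, gives 42%, the lowest number of the three. For compound 4 a downward step in this assay of moderate size, likely beyond the scatter, is therefore expected, a number 22 percentage points lower from compound 1 to compound 4 (beyond the scatter). The estimate for compound 4 is 62%, within a range from 35% to 90%.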

Compound 4, largest response reached (reported as percent of maximum), in percent of the reference or control that the assay uses: 90%
The estimate for compound 4 lay 28 percentage points below the measured number; measured number inside the range.
By their numbers in this assay, from the lowest: compound 3; then compounds 1 and 4 (each within the scatter of the next); then compound 2.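

In this assay, putting 2-(hydroxycarbamoyl)cyclopropyl in place of carboxymethoxy on this aromatic carbon, para to a large group, gives a number 6 percentage points higher from compound 1 to compound 4 (within the scatter) and so leaves the maximal response level across the change. On this core, then, the position accepts a group without a carboxylic acid, with a three-membered ring and two defined stereocentres added and seven heavy atoms entering where five left, and the read-out still cannot be told apart from that of compound 1. Nothing at hand accounts for why the maximal response holds across this exchange.

The compounds shown leave open which part of the new group matters, since the cyclopropyl and the hydroxycarbamoyl enter together: a cyclopropyl bearing a carboxylic acid or a primary amide, or the same group with its two stereocentres inverted, would separate these parts. Also open, from the compounds shown here alone, is whether the exchange carries over to the core of compound 2, and whether a maximal response that stays level here is matched by an unchanged concentration dependence, which this read-out does not report.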